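The source may report more compounds than this note shows. Statements on the series, on what has been measured and on what is new or still open speak of the compounds shown alone.

Three compounds sharing a core were tested in a functional assay on HepG2 cells (Homo sapiens) for cytotoxicity, read by MTT assay, with a stated time of 24 h; a lower number here means a stronger inhibitor, a higher number a weaker inhibitor. Compound 1 `O=c1nc2ccc(Br)cn2cc1Cc1ccc(Cl)cc1` gives > 1000000 nM, which is a limit of the assay rather than a number. Compound 3 `O=c1nc2ccc(Br)cn2cc1Cc1ccccc1` likewise reaches only the limit > 1000000 nM. Compound 2 `O=c1nc2ccc(Cl)cn2cc1Cc1ccc(F)cc1` also stops at the limit > 1000000 nM. From compound 1 to compound 3 the change is hydrogen in place of chloro on an aromatic carbon, and the step that the two limits leave unreadable from compound 1 to compound 3 stays unreadable because of the limit of > 1000000 nM in this assay, at which 3 of the 3 values shown sit. Compound 4 `O=c1nc2ccccn2cc1Cc1ccc(F)cc1`, not yet measured, differs from compound 2 by hydrogen in place of chloro on an aromatic carbon: the same kind of change, but at another place, here on a six-membered aromatic ring with one nitrogen, part of a fused or bridged system of two rings, rather than on a ring of carbon only, para to a large group. The difference between the two cores is not broken down here. In this assay compound 4 is expected to show a step of a number no higher from compound 2 to compound 4 (the limit leaves the size open), an expectation resting on the limit of > 1000000 nM in this assay, at which 3 of the 3 values shown sit, and on the unreadable a step that the two limits leave unreadable from compound 1 to compound 3. Compound 4 is estimated at 1000000 nM.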

Compound 4, half-maximal inhibitory concentration: > 1000000 nM
Compound 4 gave a limit, no number; the forecaster's own chance of this, stated with the estimate: 85%; the middle value lies on the limit itself.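

No new step can be read between compound 2 and compound 4 because both results are limits, not numbers: the limit of > 1000000 nM in this assay, at which 4 of the 4 values shown sit.

The compounds shown leave open how much replacing chloro with hydrogen changes the result in this assay, at either place.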